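Methoxy removal on two rings of an indole-type scaffold

This account rests on a few compounds, and the source may have more. Where it says the series, first, only, none or still open, it means among the compounds named here.

Compound 1 `COc1ccc2[nH]c(-c3ccccc3)c(C=C(C#N)C#N)c2c1` and compound 2 `COc1ccc(-c2[nH]c3ccc(OC)cc3c2C=C(C#N)C#N)cc1` share a core; in a functional assay on U-251 cells (Homo sapiens) for inhibition, read by sulforhodamine B assay, with a stated time of 48 h (on this read-out higher numbers stand for weaker inhibition of growth and lower numbers for stronger inhibition of growth), compound 1 gives 3500 nM, while compound 2 gives 635 nM. The change between them is hydrogen in place of methoxy on an aromatic carbon, and it produced a 5.5-fold higher number from compound 2 to compound 1 (0.74 log units; beyond the scatter). Compound 3 `COc1ccc2[nH]c(-c3ccccc3)c(/C=C(\C#N)S(=O)(=O)c3ccccc3)c2c1` carries a different core, and the difference between the two cores is not broken down here; in this assay compound 3 gives 4600 nM. Compound 4 `N#C/C(=C\c1c(-c2ccccc2)[nH]c2ccccc12)S(=O)(=O)c1ccccc1` is derived from compound 3 by hydrogen in place of methoxy on an aromatic carbon. For the measured compounds named here, this is the same kind of change as the one from compound 2 to compound 1, but the place differs: there the hydrogen entered para to a large group, whereas here it sits on a ring that is part of a fused system, meta to a fused ring and para to a fused ring. Resting only on the earlier step from compound 2 to compound 1, a smaller rise is expected, a 2.0-fold higher number from compound 3 to compound 4 (0.29 log units; within the scatter), so compound 4 is estimated at 9000 nM, between 3500 nM and 25000 nM.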

Compound 4, concentration for 50% growth inhibition: 2600 nM
For compound 4 the middle estimate is 3.5-fold (0.54 log units) above the measured one; measured number outside the range, below it.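

In this assay, for the compounds shown here, hydrogen in place of methoxy on the second core gives a 1.8-fold lower number from compound 3 to compound 4 (0.25 log units; within the scatter) and so no step that can be told from the scatter. The change therefore cannot be carried over in size from one core to the other in this series: the same change on two cores in this assay, a 5.5-fold higher number (0.74 log units; beyond the scatter) from compound 2 to compound 1 and a 1.8-fold lower number (0.25 log units; within the scatter) from compound 3 to compound 4, 9.8-fold (0.99 log units) apart, beyond the scatter of two such steps. This rests on a single pair per core with the change at a different place in each, so it does not show whether the core or the place goes with the gap, nor how any further core would respond.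

The compounds shown leave open how an ethoxy group, a chlorine atom or an amine in place of methoxy would read on either core, and whether the gap would persist with those groups.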